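The source may hold more compounds than are shown below. What is called first, only, known or untested is meant among the compounds shown, and "the series" means these compounds.

Compound 1, whose structure is `COCOc1cc(/C=C/C(=O)OCC(=O)Nc2ccc(Cl)cc2)ccc1OCc1ccccc1`, was tested in a functional assay on BEL-7404 cells (Homo sapiens) for cytotoxicity, read by MTT assay, with a stated time of 72 h; a lower number here means a stronger inhibitor, a higher number a weaker inhibitor. In that test compound 1 gave > 200000 nM, which is a limit of the assay rather than a number. Compound 2, built as `O=C(COC(=O)/C=C/c1ccc(O)c(O)c1)NN1CCOCC1`, was run in the same way. In this assay compound 2 likewise reached > 200000 nM, again a limit and not a number. Given (the limit of > 200000 nM in this assay, at which 2 of the 2 values shown sit), nothing shown sets compound 1 apart from compound 2. Compound 3, drawn as `COCOc1cc(/C=C/C(=O)OCC(=O)NCc2ccco2)ccc1OCc1ccccc1`, has not yet been measured. It differs from compound 1 in one place: (furan-2-yl)methyl in place of 4-chlorophenyl on an amide-type nitrogen, in other words (furan-2-yl)methyl in place of 4-chlorophenyl on an amide-type nitrogen. For the measured compounds named here, no step between measured compounds has been recorded, so there is no measured guide to the size of this change. The step of a number no higher from compound 1 to compound 3 (the limit leaves the size open) is expected to stay within the scatter. For compound 3 in this assay the estimated value is 200000 nM, with a range from 60000 nM to 400000 nM.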

Compound 3, half-maximal inhibitory concentration: > 200000 nM
Compound 3 was reported as a limit; the forecaster's own chance of this, stated with the estimate: 75%; the middle value lies on the limit itself.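

In this assay compound 3 gives > 200000 nM, which is a limit and not a number. Compound 1 also stands at a limit, so no step between compound 1 and compound 3 can be read: the limit of > 200000 nM in this assay, at which 3 of the 3 values shown sit.

The compounds shown leave open what number any of them would give in this assay, and so whether (furan-2-yl)methyl and 4-chlorophenyl on the amide-type nitrogen differ at all.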